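This account rests on a few compounds, and the source may have more. Where it says the series, first, only, none or still open, it means among the compounds named here.

Compound 1 `COc1cc(CNCc2ccccc2)ccc1OCc1ccc(Cl)nc1` was tested in a functional assay on HeLa cells (Homo sapiens) for inhibition, with a stated time of 72 h (on this read-out higher numbers stand for an effect only at larger amounts of compound and lower numbers for an effect already at smaller amounts), and gave 90000 nM, the highest of the two numbers obtained so far. Compound 2 `COc1cc(CNCc2ccncc2)ccc1OCc1ccc(F)cc1` in this assay gave 6400 nM, and the gap between these two values lies beyond the usual scatter. Compound 3 `COc1cc(CNCc2cccs2)ccc1OCc1ccc(Cl)nc1` has not yet been measured. It differs from compound 1 in a single place: thiophen-2-yl in place of phenyl on a saturated chain carbon bound to an amine nitrogen. Among the compounds with values here, no measured pair shows this change, so the expectation rests on compound 1 alone. Only a small step is expected, a 1.3-fold lower number from compound 1 to compound 3 (0.11 log units; within the scatter), likely within the scatter in either direction. Compound 3 is accordingly estimated at 70000 nM, with a range from 25000 nM to 200000 nM.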

Compound 3, half-maximal effective concentration: 96000 nM
Estimate against measurement, compound 3: 1.4-fold (0.14 log units) below; measured number inside the range.
By their numbers in this assay, from the lowest: compound 2; then compounds 1 and 3 (each within the scatter of the next).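

In this assay, within the data shown here, the swap of phenyl for thiophen-2-yl on a saturated chain carbon bound to an amine nitrogen gives a 1.1-fold higher number from compound 1 to compound 3 (0.03 log units; within the scatter), the first reading of a change in one place. At this position, the two aromatic rings cannot be told apart on this read-out. Nothing available bears on the reason for this result. As far as these compounds go, what a cyclohexyl or a carboxylic acid would do at this place stays open. From the compounds shown here alone, compound 2 differs from compound 1 in more than one place, so which place carries the gap between them also stays open.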